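The compounds below may be only part of what the source reports. "The series", "measured", "known", "first", "only" and "open" are said of these compounds alone.

Two compounds of this study share a large core built from a sulfonamide and an amide. Compound 1 `COc1ccc(-c2cccc(C(=O)N(C)C)c2)cc1S(=O)(=O)Nc1ccc2ccc(N(C)C(=O)c3ccccc3)cc2c1` carries a methylated amide nitrogen on one side of its core. In a functional assay on CHO cells for agonist activity at Orexin/Hypocretin receptor type 1 (Homo sapiens) (on this read-out lower numbers stand for an effect already at smaller amounts and higher numbers for an effect only at larger amounts of compound), compound 1 gives > 10000 nM, which is a limit of the assay and not a measured number. Compound 2 `COc1ccc(-c2cccc(C(=O)N(C)C)c2)cc1S(=O)(=O)Nc1ccc2cccc(NC(=O)c3ccccc3)c2c1` differs in the way its benzamide arm is attached to the core. In this assay compound 2 gives > 10000 nM, again only a limit rather than a number. So compound 2 stands at the edge of what the assay can report, and the other value shown sits there too, as the limit of > 10000 nM in this assay, at which 2 of the 2 values shown sit, records.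

Compound 3 `COc1cccc(C(=O)Nc2cccc3ccc(NS(=O)(=O)c4cc(-c5cccc(C(=O)N(C)C)c5)ccc4OC)cc23)c1` has not yet been measured. It arises from compound 2 by a small change: methoxy in place of hydrogen on an aromatic carbon, meta to a large group. Going by the values given here, with both measured compounds sitting at the limit, no step between measured compounds can guide the expectation. The step that the limit leaves unreadable from compound 2 to compound 3 is expected to be none beyond the scatter. For compound 3 the expected value in this assay is 15000 nM, with a range from 5000 nM to 50000 nM.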

Compound 3, half-maximal effective concentration: 473 nM
Compound 3: the middle estimate sits 32-fold (1.50 log units) above what was measured, outside the stated range (below it).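

On the benzamido arm of compound 2, the change to ((3-methoxyphenyl)carbonyl)amino gives, in this assay, an at least 21-fold lower number from compound 2 to compound 3 (1.32 log units; beyond the scatter). This shows that the aromatic ring of the benzamido arm is not a silent part of the molecule: a single methoxy in place of a hydrogen on one of its carbons is enough to turn a compound with no readable effect into compound 3, the only one shown here with a real number. As far as these compounds go, the true size of the step remains unknown, and it can be stated only as a bound, because the value of compound 2 is a limit and not a measured number: the limit of > 10000 nM in this assay, at which 2 of the 3 values shown sit.

The compounds shown do not tell whether this effect belongs to methoxy itself or would also appear with another group on the same carbon, such as hydroxy, fluorine, an amine or the longer ethoxy. They also leave open why the change acts as it does, and whether the same methoxy would produce a measurable effect on the arm of compound 1, which carries the methylated amide nitrogen.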